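Ester to pyrrolidine amide in a series without measurable potency

The source may report more compounds than this note shows. Statements on the series, on what has been measured and on what is new or still open speak of the compounds shown alone.

Compound 1 `COc1ccc(Nc2nc3cc(C(=O)Nc4ccccc4OC)ccc3n2Cc2ccccc2C(F)(F)F)cc1`, compound 2 `NC(=O)c1ccc2c(c1)nc(Nc1ccc(S(N)(=O)=O)cc1)n2Cc1nc2ccccc2s1` and compound 3 `COC(=O)c1ccc2c(c1)nc(Nc1ccc(S(N)(=O)=O)cc1)n2Cc1ccccc1C(F)(F)F` have been tested in an assay on isolated protein for inhibition of kinesin heavy chain isoform 5A (Homo sapiens); a higher number here means a weaker inhibitor, a lower number a stronger inhibitor. In this assay compound 1 reaches only the limit > 50000 nM. For compound 2 this assay likewise returns only the limit > 50000 nM. Compound 3 also stops at the limit > 50000 nM, so no number is known for it; all three measurements sit at the limit of > 50000 nM in this assay, at which 3 of the 3 values shown sit. Compound 4 `NS(=O)(=O)c1ccc(Nc2nc3cc(C(=O)N4CCCC4)ccc3n2Cc2ccccc2C(F)(F)F)cc1` differs from compound 3 by pyrrolidin-1-yl in place of methoxy on a carbonyl carbon. Going by the values given here, no step between measured compounds exists, and the three limits give no direction. A step that the limit leaves unreadable from compound 3 to compound 4 of no size beyond the scatter is expected. Compound 4 is estimated at 60000 nM, within 20000 nM to 200000 nM, most likely again reported only as a limit.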

Compound 4, half-maximal inhibitory concentration: > 50000 nM
Compound 4: a limit, no number; the forecaster's own chance of this, stated with the estimate: 85%; the middle value does not contradict the limit.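

Compound 3 and compound 4 give no readable step in this assay, as each value is only a limit: the limit of > 50000 nM in this assay, at which 4 of the 4 values shown sit.

The compounds shown leave open whether pyrrolidin-1-yl in place of methoxy on a carbonyl carbon alters potency, and what structure would give a measurable value.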